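This account rests on a few compounds, and the source may have more. Where it says the series, first, only, none or still open, it means among the compounds named here.

Working notes on the amidine series.

Three compounds carry numbers in a functional assay on MDA-MB-231 cells (Homo sapiens) for cytotoxicity, read by MTT assay, with a stated time of 72 h; on this read-out lower numbers stand for stronger inhibition and higher numbers for weaker inhibition. Compound 1, `N=C(Nc1ccccc1)c1cc2c(-c3ccccc3)n[nH]c2c(NC2CCCCC2)n1`, gives 1710 nM. Compound 2, `CN1CCN(c2ccc(NC(=N)c3cc4cn[nH]c4cn3)cc2)CC1`, gives 47500 nM. Compound 3, `CN1CCN(c2ccc(NC(=N)c3cc4cnn(C)c4cn3)cc2)CC1`, gives 30200 nM, which puts compound 3 second highest of the three numbers, nearest to compound 2 and furthest from compound 1.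

Within the data shown here, the one measured step that touches this pair is a 1.6-fold lower number from compound 2 to compound 3 (0.20 log units; within the scatter), so the methyl on the aromatic nitrogen left the number effectively unchanged.

Compound 4, `CN1CCN(c2ccc(NC(=N)c3cc4c(-c5ccccc5)nn(C)c4cn3)cc2)CC1`, is the next step: phenyl in place of hydrogen on an aromatic carbon. Among the measured compounds shown here, no measured pair shows this exact change on the shared core. Compound 1 does carry a phenyl and gives a far lower number than compound 3, but compound 1 differs from compound 3 in several other places at once, so its number is only a loose hint.

The step into compound 4 is therefore expected to lower the number, likely by a 3.0-fold lower number from compound 3 to compound 4 (0.48 log units; beyond the scatter), with wide uncertainty. Compound 4 is estimated at 10000 nM, within a range of 3000 nM to 30000 nM in this assay.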

Compound 4, half-maximal inhibitory concentration: 4900 nM
The estimate for compound 4 lay 2.0-fold (0.31 log units) above the measured number; measured number inside the range.
By their numbers in this assay, from the lowest: compound 1; then compound 4; then compounds 3 and 2 (each within the scatter of the next).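

In this assay, phenyl in place of hydrogen on an aromatic carbon gives a 6.2-fold lower number from compound 3 to compound 4 (0.79 log units; beyond the scatter) and is the only single-place step on the shared core shown to lie beyond the scatter. This carbon of the five-membered aromatic ring, next to the ring nitrogen, is therefore a position where a change moves the number, whereas the methyl on the aromatic nitrogen gave only a 1.6-fold lower number from compound 2 to compound 3 (0.20 log units; within the scatter) and stayed within the scatter. No supporting measurement bears on what lies behind this step.

From the compounds shown here alone, it remains open whether the step is specific to phenyl or would also hold for a methyl group, an amine or a pyridyl ring on the same carbon. Also open, going by these compounds, is whether phenyl has the same effect when the aromatic nitrogen carries hydrogen instead of methyl.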